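Propyl-to-iodo swap on the arylurea series

The source may hold more compounds than are shown below. What is called first, only, known or untested is meant among the compounds shown, and "the series" means these compounds.

Measured so far:
compound 1 `CCCc1ccc(NC(=O)N[C@H](C)c2ccccc2)cc1` — 33%
compound 2 `CCCc1ccc(NC(=O)N[C@@H](C)c2ccccc2)cc1` — 97%
compound 3 `C[C@@H](NC(=O)Nc1cccc(Cl)c1)c1ccccc1` — 97%

In an ADME assay on the whole organism with Oryza sativa as the target, tested at 0.1 uM (on this read-out lower numbers stand for a stronger effect and higher numbers for a weaker effect at the one concentration tested), compound 1 gives the lowest of the three numbers, i.e. the strongest effect seen at this concentration. Compound 2 sits a number 64 percentage points higher from compound 1 to compound 2 (beyond the scatter), a change that rests on (the fact that compounds 1 and 2 differ only in the configuration as drawn), so it speaks only to the drawn configuration and not to substitution on the aryl ring. Among the compounds with values here, compound 3 carries a chloro group on a different aryl pattern and gives 97%, a number matching that of compound 2; no single-point step connects compound 3 to compound 1, so only the two values themselves can be read.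

Compound 4 `C[C@@H](NC(=O)Nc1ccc(I)cc1)c1ccccc1` differs from compound 1 as follows: iodo in place of propyl on an aromatic carbon. Within the data shown here, no measured step here isolates a change on that aromatic carbon, so the expectation has to be wide. Given that compound 1 holds the low end and the other two compounds both sit high, a step back toward the high values is thought more likely than a further fall; in this assay compound 4 is expected to give 55% (range 20% to 95%), which is estimated to mean a number 22 percentage points higher from compound 1 to compound 4 (beyond the scatter).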

Compound 4, a percentage reported as activity, at one concentration (the size of the read-out at that concentration, not a potency): 100%
The estimate for compound 4 lay 45 percentage points below the measured number, and the stated range ends below it.
By their numbers in this assay, from the lowest: compound 1; then compounds 2, 3 and 4 (each within the scatter of the next).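

In this assay, iodo in place of propyl on the aromatic carbon gives a number 67 percentage points higher from compound 1 to compound 4 (beyond the scatter), which makes this place, para to a large group, the first point on the aryl ring shown to carry a large step in a single change. The low number of compound 1 therefore does not follow from the drawn configuration alone: with that configuration unchanged, propyl at this place goes with the low number and iodo with a high one, so the earlier step between the two mirror-drawn compounds was only part of the picture. The material at hand gives no cause for this step, and it cannot say which difference between the two groups matters, whether the carbon chain or the iodine atom.

On these data alone, what stays open is whether the low number depends on the length of the chain: an ethyl group or a butyl chain at this aromatic carbon would test that directly. A methoxy group or an amine at the same place would show whether anything other than an alkyl chain can keep the number low.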